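Moving the methoxy group of compound 2

The source may report more compounds than this note shows. Statements on the series, on what has been measured and on what is new or still open speak of the compounds shown alone.

- Compound 1 `O=C(/C(=C\c1ccc(Br)cc1)Sc1ccc(Br)cc1)c1ccc(Cl)cc1`: 1000 nM
- Compound 2 `COc1ccc(/C=C(/Sc2ccc(Br)cc2)C(=O)c2ccc(Cl)cc2)cc1`: 50000 nM

In a functional assay on DU-145 cells (Homo sapiens) for inhibition, read by trypan blue exclusion, with a stated time of 96 h (a higher number here means a weaker inhibitor of growth, a lower number a stronger inhibitor of growth), compound 2 gives 50000 nM, the higher of the two numbers, which makes it the weaker growth inhibitor of the pair. The next compound, compound 3 `COc1ccccc1/C=C(/Sc1ccc(Br)cc1)C(=O)c1ccc(Cl)cc1`, contains the same atoms joined differently: 2-methoxyphenyl in place of 4-methoxyphenyl on a double-bonded chain carbon bound to a double-bonded chain carbon.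

For the measured compounds named here, only one measured step bears on this change: a 50-fold higher number from compound 1 to compound 2 (1.70 log units; beyond the scatter). This large step, well beyond the scatter, came from methoxy in place of bromo on an aromatic carbon. It shows that the group at this part of the structure can matter greatly in this assay. However, no measured compound carries 2-methoxyphenyl, so the data do not show what moving the methoxy will do.

Compound 1, at 1000 nM, shows that much lower numbers are reachable, so a moderate fall is expected, with no real change still possible. The expected step is a 4.2-fold lower number from compound 2 to compound 3 (0.62 log units; beyond the scatter). For compound 3 the estimated value is 12000 nM, with an expected range of 2000 nM to 60000 nM.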

Compound 3, concentration for 50% growth inhibition: 10000 nM
The estimate for compound 3 lay 1.2-fold (0.08 log units) above the measured number; the range from low to high includes it.
By their numbers in this assay, from the lowest: compound 1; then compound 3; then compound 2.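

Moving the methoxy group changes no atom count, yet it gives a 5.0-fold lower number from compound 2 to compound 3 (0.70 log units; beyond the scatter) in this assay. This shows that where a group sits on this ring can matter as well as which group it is, something the earlier swap of bromo for methoxy could not separate. The move recovers only part of what that swap lost, however: there is still a 10-fold higher number from compound 1 to compound 3 (1.00 log units; beyond the scatter), so among the three groups shown on a double-bonded chain carbon bound to a double-bonded chain carbon, 4-bromophenyl gives the strongest growth inhibitor, and neither methoxyphenyl group matches it. Nothing available explains why 2-methoxyphenyl and 4-methoxyphenyl differ, or why either falls short of 4-bromophenyl.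

The compounds shown leave open whether moving the bromo of compound 1 in the same way would also shift the number, and in which direction, since the effect of moving a group is seen here for methoxy alone. They also leave open how other groups on this ring, such as an amine, a carboxylic acid or a trifluoromethyl, would compare with bromo and methoxy.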